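The source may hold more compounds than are shown below. What is called first, only, known or untested is meant among the compounds shown, and "the series" means these compounds.

Going by the values given here, compound 1 `O=C(c1ccccc1)N1CCC(NS(=O)(=O)c2cc(S(=O)(=O)c3ccccc3)ccc2C(F)(F)F)CC1` is one of three compounds measured in an assay on isolated protein for displacement of a labelled ligand from secreted frizzled-related protein 1 (Homo sapiens), read by fluorescence polarization, with a stated time of 30 min; a higher number here means a weaker inhibitor, a lower number a stronger inhibitor. In this assay compound 1 gives 70 nM, the second highest of the three numbers. Compound 2 `O=C(c1ccc(Cl)nc1)N1CCC(NS(=O)(=O)c2cc(S(=O)(=O)c3ccccc3)ccc2C(F)(F)F)CC1` gives 110 nM in this assay, and compound 3 `O=C([C@H]1CCNC1)N1CCC(NS(=O)(=O)c2cc(S(=O)(=O)c3ccccc3)ccc2C(F)(F)F)CC1` gives 40 nM. The measured steps are a 1.6-fold higher number from compound 1 to compound 2 (0.20 log units; within the scatter), a 1.8-fold lower number from compound 1 to compound 3 (0.24 log units; within the scatter) and a 2.8-fold lower number from compound 2 to compound 3 (0.44 log units; beyond the scatter).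

Compound 4 `O=C([C@@H]1CCNC1)N1CCC(NS(=O)(=O)c2cc(S(=O)(=O)c3ccccc3)ccc2C(F)(F)F)CC1` differs from compound 1 in this way: pyrrolidin-3-yl in place of phenyl on a carbonyl carbon. Compound 4 carries the same entering group as compound 3, with the opposite configuration at its defined stereocentre. The step that bears most directly on compound 4 is therefore a 1.8-fold lower number from compound 1 to compound 3 (0.24 log units; within the scatter), which stayed within the scatter. Among the compounds with values here, no measured pair tells how the two configurations compare. The author expects the step from compound 1 to compound 4 in this assay to be small, at most a 1.2-fold lower number from compound 1 to compound 4 (0.07 log units; within the scatter), and most likely within the scatter. Compound 4 is estimated at 60 nM in this assay, in a range from 25 nM to 150 nM.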

Compound 4, half-maximal inhibitory concentration: 60 nM
For compound 4 middle estimate and measured number coincide at the digits printed; the measured number falls inside the stated range.
By their numbers in this assay, from the lowest: compounds 3, 4, 1 and 2 (each within the scatter of the next, the first and the last beyond it).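

Turning over the stereocentre of the pyrrolidin-3-yl group gives a 1.5-fold higher number from compound 3 to compound 4 (0.18 log units; within the scatter), so in this assay the drawn configuration at this saturated ring carbon has no effect that can be told from the scatter. With this configuration too, pyrrolidin-3-yl on the carbonyl carbon stays within the scatter of the aromatic groups, with a 1.2-fold lower number from compound 1 to compound 4 (0.07 log units; within the scatter) and a 1.8-fold lower number from compound 2 to compound 4 (0.26 log units; within the scatter). The comparison of the two configurations is a clean one, and it rests on a single point: the fact that compounds 3 and 4 differ only in the configuration as drawn

Going by these compounds, whether the ring nitrogen of pyrrolidin-3-yl matters at this position stays open, and a cyclopentyl group on the same carbonyl carbon would speak to that. On these data alone, how a larger saturated ring such as piperidin-4-yl or an open-chain amine would read here also remains unknown.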